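From 2-fluorobenzyl to 3-methylbenzyl: compound 1 to compound 4

The source may report more compounds than this note shows. Statements on the series, on what has been measured and on what is new or still open speak of the compounds shown alone.

Measured so far in an ADME assay on L929 cells (Mus musculus) for cytotoxicity, read by microscopy, with a stated time of 96 h; a lower number here means that less compound is tolerated, a higher number that more compound is tolerated:
- compound 1 `Cc1n[nH]c2c1[C@@H](c1ccc(OCc3ccccc3F)cc1)S[C@@H](C)C(=O)N2`: > 200000 nM (a limit)
- compound 2 `Cc1n[nH]c2c1[C@@H](c1ccc(OCc3cccc(F)c3)cc1)S[C@@H](C)C(=O)N2`: 103000 nM
- compound 3 `Cc1ccccc1COc1ccc([C@H]2S[C@@H](C)C(=O)Nc3[nH]nc(C)c32)cc1`: 111000 nM

Compound 1 stands at the limit of > 200000 nM in this assay, at which 1 of the 3 values shown sits. That value is a limit, not a number.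

Compound 4 `Cc1cccc(COc2ccc([C@H]3S[C@@H](C)C(=O)Nc4[nH]nc(C)c43)cc2)c1` keeps the core of compound 1 and carries 3-methylphenyl in place of 2-fluorophenyl on a saturated chain carbon bound to an oxygen on an aromatic ring.

Among the compounds with values here, three measured steps bear on this change. The change to 3-fluorophenyl gives an at least 1.9-fold lower number from compound 1 to compound 2 (0.28 log units; that floor lies within the scatter). Methyl in place of fluoro on an aromatic carbon gives an at least 1.8-fold lower number from compound 1 to compound 3 (0.25 log units; that floor lies within the scatter). The swap of 3-fluorophenyl for 2-methylphenyl gives a 1.1-fold higher number from compound 2 to compound 3 (0.03 log units; within the scatter). The new group combines features of both neighbours, so compound 4 is expected to sit close to compound 2 at 103000 nM and compound 3 at 111000 nM. In this assay a step towards a lower number is therefore expected, of about the size of the first two steps, with a floor that may not clear the scatter.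

For compound 4 the estimated value is 110000 nM, with an expected range of 60000 nM to 190000 nM.

The expected step is an at least 1.8-fold lower number from compound 1 to compound 4 (0.25 log units; that floor lies within the scatter).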

Compound 4, concentration lethal to 50% of the cells: 98900 nM
Beside the measured number, compound 4's estimate is 1.1-fold (0.05 log units) above it; the range from low to high includes it.
By their numbers in this assay, from the lowest: compounds 4, 2 and 3 (each within the scatter of the next). At a limit, above all of these: compound 1.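

In this assay, compound 4 fills out the set of methyl and fluoro groups at these places on the benzyl ring: 3-methylphenyl in place of 2-methylphenyl gives a 1.1-fold lower number from compound 3 to compound 4 (0.05 log units; within the scatter), and methyl in place of fluoro on an aromatic carbon gives a 1.0-fold lower number from compound 2 to compound 4 (0.02 log units; within the scatter), so neither change separates these compounds. Compound 1 gives > 200000 nM, which is a limit and not a number. Within the data shown here, the change from 2-fluorophenyl to 3-methylphenyl gives an at least 2.0-fold lower number from compound 1 to compound 4 (0.30 log units; that floor lies within the scatter), which is only a floor, so the full size of this step stays unknown and compound 1 remains the one compound of the four without a numerical place.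

Going by these compounds, whether methyl in place of fluoro has the same size of effect when it starts from 2-fluorophenyl as when it starts from 3-fluorophenyl stays open: the same change on two cores in this assay, an at least 1.8-fold lower number (0.25 log units; that floor lies within the scatter) from compound 1 to compound 3 and a 1.0-fold lower number (0.02 log units; within the scatter) from compound 2 to compound 4; the limit leaves it open whether they differ Whether an amine or a carboxylic acid on the benzyl ring would move the number in this assay beyond the scatter also stays open.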